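The compounds below may be only part of what the source reports. "The series", "measured", "known", "first", "only" and "open" are said of these compounds alone.

Among the measured compounds shown here, in a functional assay on cells (Neutrophil, Homo sapiens) for inhibition, read by transwell migration (on this read-out higher numbers stand for weaker inhibition and lower numbers for stronger inhibition), three compounds sharing one core have numbers so far. Compound 1 `COC(=O)c1c(NCCN(C)C)n(-c2ccccc2)c(=S)n(-c2ccccc2)c1=O` gives 3.32 nM, compound 2 `CCOC(=O)c1c(NCCN(CC)CC)n(-c2ccccc2)c(=S)n(-c2ccccc2)c1=O` gives 0.02 nM, and compound 3 `CCOC(=O)c1c(NCCCN(C)C)n(-c2ccccc2)c(=S)n(-c2ccccc2)c1=O` gives 3.89 nM. Compound 3 and compound 1 lie within the scatter of each other, while the number of compound 2 lies far from both.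

Compound 4 `CCOC(=O)c1c(NCCC2CCCN2C)n(-c2ccccc2)c(=S)n(-c2ccccc2)c1=O` keeps everything in compound 3 except one group: 1-methylpyrrolidin-2-yl in place of (dimethylamino)methyl on a saturated chain carbon, two bonds along the chain from a nitrogen on an aromatic ring. Here 1-methylpyrrolidin-2-yl stands in place of (dimethylamino)methyl on a saturated chain carbon, two bonds along the chain from a nitrogen on an aromatic ring.

For the measured compounds named here, one measured step bears on this change, at the same place: a 190-fold higher number from compound 2 to compound 3 (2.29 log units; beyond the scatter), a large step in which (dimethylamino)methyl took the place of diethylamino. It shows that a swap at this carbon can move the number a long way in this assay. Going by the values given here, no measured compound carries the new ring, however, so the size of the next step cannot be read directly from the data. Among the compounds with values here, with a 190-fold higher number from compound 2 to compound 3 (2.29 log units; beyond the scatter) as the only guide, a move towards a lower number is expected, much smaller than that step and quite uncertain.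

The estimated change is a 3.9-fold lower number from compound 3 to compound 4 (0.59 log units; beyond the scatter). Compound 4 is expected at 1 nM, with an estimated range from 0.1 nM to 8 nM.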

Compound 4, half-maximal inhibitory concentration: 1.61 nM
Compound 4: the middle estimate sits 1.6-fold (0.21 log units) below what was measured; measured number inside the range.
By their numbers in this assay, from the lowest: compound 2; then compound 4; then compounds 1 and 3 (each within the scatter of the next).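

In this assay, putting 1-methylpyrrolidin-2-yl in place of (dimethylamino)methyl on this saturated chain carbon gives a 2.4-fold lower number from compound 3 to compound 4 (0.38 log units; beyond the scatter) and so shows that a five-membered non-aromatic ring can stand at this place with only a modest shift, in contrast to the large step seen earlier at the same carbon. The ring does not close the gap to diethylamino, since an 81-fold higher number from compound 2 to compound 4 (1.91 log units; beyond the scatter) remains in this assay and compound 2 keeps the lowest number of the three compounds that differ at this place. No measurement is at hand that would explain the size of either step.

The compounds shown leave open whether a piperidin-1-yl or pyrrolidin-1-yl group at this carbon, or a dipropylamino group, would bring the number closer to that of compound 2. They also leave open whether the modest step seen with the 1-methylpyrrolidin-2-yl group would hold with a methyl ester in place of the ethyl ester on the shared core.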